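This account rests on a few compounds, and the source may have more. Where it says the series, first, only, none or still open, it means among the compounds named here.

In an ADME assay on Vero 76 cells (Chlorocebus sabaeus) for cytotoxicity (on this read-out higher numbers stand for lower toxicity in this test and lower numbers for higher toxicity in this test), compound 1 `Nc1ncc(F)c2c1ncn2[C@@H]1C=C(CO)[C@@H](O)[C@H]1O` gives 36000 nM, while compound 2 `Nc1ncc(F)c2c1ncn2[C@@H]1C=C(CCO)[C@@H](O)[C@H]1O` gives 3400 nM. Compound 1 therefore holds the higher of the two numbers and is the less toxic of the pair in this test. The next structure, compound 3 `Cc1cnc(N)c2ncn([C@@H]3C=C(CO)[C@@H](O)[C@H]3O)c12`, keeps the hydroxymethyl group of compound 1 and changes the shared core: methyl in place of fluoro on an aromatic carbon. Going by the values given here, the only measured step, an 11-fold lower number from compound 1 to compound 2 (1.02 log units; beyond the scatter), is a large one, but it lies on a saturated chain carbon and not on this aromatic carbon. It shows that this assay can respond strongly to a small edit, yet it gives no direction for this swap. The estimated step is a 1.2-fold lower number from compound 1 to compound 3 (0.08 log units; within the scatter), with no shift beyond the scatter expected. For compound 3 the estimated value is 30000 nM, with an expected range from 8000 nM to 100000 nM.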

Compound 3, half-maximal cytotoxic concentration: 36000 nM
Estimate against measurement, compound 3: 1.2-fold (0.08 log units) below, and the stated range covers the measured number.
By their numbers in this assay, from the lowest: compound 2; then compounds 1 and 3 (each within the scatter of the next).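

In this assay, methyl in place of fluoro on the aromatic carbon para to an amino group gives no change at the digits printed from compound 1 to compound 3 (within the scatter), so on this carbon the fluoro group can be exchanged for methyl without a shift beyond the usual scatter. The earlier step, an 11-fold lower number from compound 1 to compound 2 (1.02 log units; beyond the scatter), showed a large response to an edit on the saturated chain, while this swap shows that not every small edit moves the number and that fluoro is not needed here to keep it high. Nothing available explains why compounds with these two groups read alike.

The compounds shown leave open whether other groups on this aromatic carbon, such as chloro, an amine or a nitrile, would also leave the number in place. They also leave open whether methyl would read the same alongside the longer chain of compound 2.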